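Carbonyl substituent changes within the series

The source may report more compounds than this note shows. Statements on the series, on what has been measured and on what is new or still open speak of the compounds shown alone.

Compound 3 `O=C(O)/C=C/c1ccncc1-c1ccc2ccccc2c1` gives 102% in an assay on a protein complex for inhibition of CDK8/Cyclin C (Homo sapiens), with a stated time of 1 h, tested at 10 uM; a higher number here means more inhibition at the concentration tested (going by the name of the read-out), a lower number less inhibition. It stands level with compound 2 `COC(=O)/C=C/c1ccncc1-c1ccc2ccccc2c1` at 102%, the two together the highest of the three numbers, and its furthest neighbour is compound 1 `CNC(=O)/C=C/c1ccncc1-c1ccc2ccccc2c1` at 101%. The steps among these, no change at the digits printed from compound 2 to compound 3 (within the scatter) and a number 1 percentage points higher from compound 1 to compound 3 (within the scatter), as well as a number 1 percentage points higher from compound 1 to compound 2 (within the scatter), all lie within the scatter. Compound 4 `CN(C)C(=O)/C=C/c1ccncc1-c1ccc2ccccc2c1` differs from compound 3 by dimethylamino in place of hydroxy on a carbonyl carbon. The earlier exchanges on the same carbonyl carbon, methoxy for methylamino and hydroxy for methylamino, bear on this step and were small. A step of a number 2 percentage points lower from compound 3 to compound 4 (within the scatter) is therefore expected, none beyond the scatter. The estimate for compound 4 in this assay is 100%, within 88% to 105%.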

Compound 4, a percentage reported as inhibition, at one concentration (the size of the read-out at that concentration, not a potency): 100%
The estimate for compound 4 equals the measured number at the digits printed; the range from low to high includes it.
By their numbers in this assay, from the lowest: compounds 4, 1, 2 and 3 (each within the scatter of the next).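

In this assay, the carbonyl carbon also accepts dimethylamino, which carries no hydrogen-bond donor, whereas the hydroxy it replaces carries one: the change gives a number 2 percentage points lower from compound 3 to compound 4 (within the scatter) and, against methoxy, a number 2 percentage points lower from compound 2 to compound 4 (within the scatter). Adding a methyl in place of the amide hydrogen also leaves the number within the scatter (a number 1 percentage points lower from compound 1 to compound 4 (within the scatter)). No supporting measurement is available to explain this flat response.

Still open, from the compounds shown here alone, is whether an unsubstituted amide, a morpholine amide or a longer chain on the amide nitrogen stays level with these compounds. A single-concentration read-out this uniform also gives no potency order among compounds 1 to 4.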